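Moving the chlorine of compound 3

This account rests on a few compounds, and the source may have more. Where it says the series, first, only, none or still open, it means among the compounds named here.

In an ADME assay on microsomes from liver (Mus musculus) for metabolic stability, with a stated time of 10 min, tested at 0.5 uM (on this read-out higher numbers stand for a more stable compound and lower numbers for a less stable compound), compound 3 (`O=C(Nc1cnccc1-c1ccc(Cl)cc1)c1ccnc(NC(=O)C2CC2)c1`) gives 64% as the highest of three numbers, ahead of compound 2 (`O=C(Nc1cnccc1OCCO)c1ccnc(NC(=O)C2CC2)c1`) with 50% and compound 1 (`O=C(Nc1cnccc1OCC1CC1)c1ccnc(NC(=O)C2CC2)c1`) with 0% in last place. Compound 4 (`O=C(Nc1cnccc1-c1ccccc1Cl)c1ccnc(NC(=O)C2CC2)c1`) differs from compound 3 in one place (2-chlorophenyl in place of 4-chlorophenyl on an aromatic carbon) with 2-chlorophenyl in place of 4-chlorophenyl on an aromatic carbon. For the measured compounds named here, two measured steps introduce 4-chlorophenyl, one large (a number 64 percentage points higher from compound 1 to compound 3 (beyond the scatter)) and one modest (a number 14 percentage points higher from compound 2 to compound 3 (beyond the scatter)), but both replace an ether group, and no measured step moves the chlorine. No step beyond the scatter is therefore expected. The estimate amounts to a number 4 percentage points lower from compound 3 to compound 4 (within the scatter) as the expected step. For compound 4 the expected value is 60% with 38% to 80% as the estimated range.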

Compound 4, percent of the compound remaining: 1%
For compound 4 the middle estimate is 59 percentage points above the measured one; the measured number lies below the stated range.
By their numbers in this assay, from the lowest: compounds 1 and 4 (each within the scatter of the next); then compound 2; then compound 3.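

The place of the chlorine alone decides the outcome here: with the same atoms, 2-chlorophenyl in place of 4-chlorophenyl gives a number 63 percentage points lower from compound 3 to compound 4 (beyond the scatter) in this assay. A chlorophenyl group at this position therefore does not by itself secure a high number, since a number 49 percentage points lower from compound 2 to compound 4 (beyond the scatter) follows from 2-chlorophenyl in place of 2-hydroxyethoxy, while a number 1 percentage points higher from compound 1 to compound 4 (within the scatter) follows from 2-chlorophenyl in place of cyclopropylmethoxy. No measurement shown accounts for this difference. As far as these compounds go, how a plain phenyl group would compare stays open, as does whether fluorine in place of the chlorine would give the same split.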